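Aryl oxoacetamides: ester-to-amide change on the benzoate side

The source may report more compounds than this note shows. Statements on the series, on what has been measured and on what is new or still open speak of the compounds shown alone.

Measured so far:
compound 1, `CCOC(=O)c1ccc(NC(=O)C(=O)c2ccccc2NC(C)=O)cc1`, 990000 nM in an assay on mitochondria from brain for inhibition of Amine oxidase [flavin-containing] B (Bos taurus); a lower number here means a stronger inhibitor, a higher number a weaker inhibitor
compound 2, `COC(=O)C[C@H](NC(=O)C(=O)c1ccccc1NC(C)=O)C(=O)OC`, 460000 nM in this assay
compound 3, `COC(=O)CCCCCNC(=O)C(=O)c1ccccc1NC(C)=O`, 590000 nM in this assay

All three compounds share the acetamidophenyl oxoacetamide core and all give very high numbers in this assay. Compound 1 stands at the highest of the three numbers; its gap to compound 3 lies within the usual scatter, so the two cannot be told apart, while its gap to compound 2 lies beyond the scatter. Among the measured compounds shown here, no step between compounds differing in one place is available, so nothing measured says how a change on the ester carbonyl moves the number.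

Compound 4, `COC(=O)[C@H](C)NC(=O)c1ccc(NC(=O)C(=O)c2ccccc2NC(C)=O)cc1`, differs from compound 1 by (1-(methoxycarbonyl)ethyl)amino in place of ethoxy on a carbonyl carbon. The three measured numbers lie close together despite quite different groups on the oxoacetamide nitrogen, so the step is expected to be none beyond the scatter, a 1.1-fold lower number from compound 1 to compound 4 (0.04 log units; within the scatter). Compound 4 is therefore estimated at 900000 nM, within 300000 nM to 3000000 nM, with a real chance that this assay reports only a limit.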

Compound 4, half-maximal inhibitory concentration: 730000 nM
Beside the measured number, compound 4's estimate is 1.2-fold (0.09 log units) above it; measured number inside the range.
By their numbers in this assay, from the lowest: compounds 2, 3, 4 and 1 (each within the scatter of the next, the first and the last beyond it).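

Among the compounds shown here, this is the only one-place step so far: (1-(methoxycarbonyl)ethyl)amino in place of ethoxy on a carbonyl carbon gives a 1.4-fold lower number from compound 1 to compound 4 (0.13 log units; within the scatter) in this assay. A larger entering group, carrying a hydrogen-bond donor and a defined stereocentre, therefore leaves compound 4 indistinguishable from compound 1 at this position, so this change gives no usable handle on the number. Nothing available bears on the reason for this result.

Open, from the compounds shown here alone, is whether a carboxylic acid in place of the methoxycarbonyl, a simple amine on the same carbonyl carbon, or a longer chain would move the number beyond the scatter. Going by these compounds, the opposite configuration at the stereocentre of the entering group also remains open.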